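A few compounds are considered here, and "the series" means these few. Any claim that something is new, unique, unknown or untested is made for them only; others in the source may bear on it.

Three compounds of the series carry numbers in a functional assay on BXPC-3 cells (Homo sapiens) for inhibition, read by MTT assay, with a stated time of 72 h; a higher number here means a weaker inhibitor, a lower number a stronger inhibitor. In this assay compound 1 `O=C(Nc1cccc2cccnc12)c1cccc(Br)n1` reaches only the limit, > 10000 nM (the limit of > 10000 nM in this assay, at which 1 of the 3 values shown sits), a limit and not a number. Compound 2 `Cc1cnc(C(=O)Nc2cc(Cl)cc3cccnc23)cn1` gives 5200 nM, and compound 3 `COc1cc(NC(=O)c2cnc(C)cn2)c2ncccc2c1` gives 6700 nM. For the measured compounds named here, the single measured step, a 1.3-fold higher number from compound 2 to compound 3 (0.11 log units; within the scatter), leaves the two within the scatter, so compound 3 stands beside compound 2 with no order between them, and apart from the limit of compound 1. Compound 4 `COc1cc(NC(=O)c2cnccn2)c2ncccc2c1` differs from compound 3 by hydrogen in place of methyl on an aromatic carbon. Going by the values given here, no measured step touches this ring; none therefore bears on the change, and no step beyond the scatter is expected. Compound 4 is expected at 8000 nM, with a range from 3500 nM to 20000 nM, as compound 3 gives 6700 nM. The expected step is a 1.2-fold higher number from compound 3 to compound 4 (0.08 log units; within the scatter).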

Compound 4, half-maximal inhibitory concentration: 470 nM
Compound 4: middle estimate off by 17-fold (1.23 log units), on the high side; the whole stated range lies above it.
By their numbers in this assay, from the lowest: compound 4; then compounds 2 and 3 (each within the scatter of the next). At a limit, above all of these: compound 1.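

In this assay the change from 5-methylpyrazin-2-yl to pyrazin-2-yl gives a 14-fold lower number from compound 3 to compound 4 (1.15 log units; beyond the scatter). For the compounds shown here, this aromatic carbon, next to the ring nitrogen and para to a large group, is therefore a place where one methyl separates the two numbers, something the earlier compounds could not show, as their only measured step lay elsewhere and within the scatter. Nothing shown here accounts for the size of this step.

Open, on these data alone, is how an amine or a longer chain such as ethyl would read at this carbon. Also open, as far as these compounds go, is whether removing the methyl has the same effect with chloro in place of methoxy.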